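Swapping the aminophenyl for dichlorophenyl on a pyrazole chalcone

The source may report more compounds than this note shows. Statements on the series, on what has been measured and on what is new or still open speak of the compounds shown alone.

Measured compounds:
compound 1 `COc1ccc(-c2cc(/C=C/C(=O)c3ccc(N)cc3)[nH]n2)cc1` with -93%
compound 2 `COc1cc(-c2cc(/C=C/C(=O)c3ccc(N)cc3)[nH]n2)cc(OC)c1OC` with -92%

In a functional assay on UACC-62 cells (Homo sapiens) for cytotoxicity, read by sulforhodamine B assay, with a stated time of 48 h, tested at 100 uM (a lower number here means a stronger effect, a higher number a weaker effect of the compound at the concentration tested), compound 2 gives -92%, and compound 1 gives -93%; the two numbers sit within the scatter of each other, so neither stands apart. Compound 3 `COc1cc(-c2cc(/C=C/C(=O)c3ccc(Cl)c(Cl)c3)[nH]n2)cc(OC)c1OC` is not yet measured. It differs from compound 2 in one place: 3,4-dichlorophenyl in place of 4-aminophenyl on a carbonyl carbon. Within the data shown here, with no measured step of this kind to lean on, the expectation is a step of a number 7 percentage points higher from compound 2 to compound 3 (within the scatter), a modest move toward a weaker effect that may stay within the scatter. Compound 3 is therefore estimated at -85%, with a range from -100% to -55%.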

Compound 3, a percentage reported as activity, at one concentration (the size of the read-out at that concentration, not a potency): 14%
Compound 3: middle estimate off by 99 percentage points, on the low side, outside the stated range (above it).
By their numbers in this assay, from the lowest: compounds 1 and 2 (each within the scatter of the next); then compound 3.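

In this assay, the group on the carbonyl carbon matters greatly: 3,4-dichlorophenyl in place of 4-aminophenyl gives a number 106 percentage points higher from compound 2 to compound 3 (beyond the scatter), towards a much weaker effect. Compound 1 and compound 2 both carry 4-aminophenyl here, so they could not reveal this sensitivity. Nothing available explains the size of this step.

As far as these compounds go, this single swap removes the amine and adds two chlorines at once, so it remains open which of these changes matters. The compounds shown also leave open how 4-chlorophenyl or 4-hydroxyphenyl would behave on this carbonyl carbon.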